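Linker exchange on the aniline arm: an expected inhibition

The source may hold more compounds than are shown below. What is called first, only, known or untested is meant among the compounds shown, and "the series" means these compounds.

Measured so far:
compound 1, `CN(C)C(=O)c1cc2cnc(Nc3ccc(S(=O)(=O)NCCCCN=C=S)cc3)nc2n1C1CCCC1`: 101%
compound 2, `CN(C)C(=O)c1cc2cnc(Nc3ccc(C(=O)NCCCCCCN=C=S)cc3F)nc2n1C1CCCC1`: 22.9%

In a functional assay on A549 cells (Homo sapiens) for inhibition, read by CCK-8 assay, with a stated time of 72 h, tested at 10 uM (a lower number here means a weaker effect, a higher number a stronger effect of the compound at the concentration tested), compound 1 gives 101%, the highest of the two numbers; compound 2 gives 22.9%, a gap beyond the usual scatter. Compound 3, `CN(C)C(=O)c1cc2cnc(Nc3ccc(NC(=O)CCCCN=C=S)cc3)nc2n1C1CCCC1`, is not yet measured. It differs from compound 1 by a group of 10 heavy atoms (6 carbon, 2 nitrogen, 1 oxygen, 1 sulfur; no ring) in place of a group of 11 heavy atoms (5 carbon, 2 nitrogen, 2 oxygen, 2 sulfur; no ring), on an aromatic carbon. Among the measured compounds shown here, no pair of measured compounds isolates this change, so the expectation rests on compound 1 alone, which gives 101%. A moderate loss is expected, the step from compound 1 to compound 3 being estimated as a number 36 percentage points lower from compound 1 to compound 3 (beyond the scatter). Compound 3 is thus expected near 65%, between 25% and 100%.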

Compound 3, a percentage reported as inhibition, at one concentration (the size of the read-out at that concentration, not a potency): 102%
Compound 3: middle estimate off by 37 percentage points, on the low side; the measured number lies above the stated range.
By their numbers in this assay, from the lowest: compound 2; then compounds 1 and 3 (each within the scatter of the next).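

In this assay, exchanging the sulfonamide-linked arm for an amide-linked arm on this aromatic carbon gives a number 1 percentage points higher from compound 1 to compound 3 (within the scatter). Among the compounds shown here, this position therefore accepts either linker at the tested concentration, something the earlier compounds could not show, since they differ in more than one place. A read-out at one concentration gives the size of the effect and not potency, so any difference in potency stays hidden. Still open, as far as these compounds go, is whether an amine or a carboxylic acid at the end of the arm, in place of the isothiocyanate, would keep this effect. No measurement here explains the result.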